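Benzothiazole oximes: CHO cytotoxicity notes

A few compounds are considered here, and "the series" means these few. Any claim that something is new, unique, unknown or untested is made for them only; others in the source may bear on it.

Measured compounds:
compound 1, `C/C(=N\O)c1nc2ccccc2s1`, > 100000 nM
compound 2, `Cc1nc(/C(=N\O)c2nc3ccccc3s2)no1`, "not determined" (no result reported)
compound 3, `CON=C(c1nc2ccccc2s1)c1nc2ccccc2s1`, > 50000 nM

The read-out throughout is an ADME assay on CHO cells (Cricetulus griseus) for cytotoxicity; a lower number here means a stronger inhibitor, a higher number a weaker inhibitor. For compound 1 the value is a limit of the assay, not a number; this is the case summarised as the limit of > 100000 nM in this assay, at which 1 of the 3 values shown sits. For compound 3 the value is likewise a limit, the case summarised as the limit of > 50000 nM in this assay, at which 1 of the 3 values shown sits. Compound 2 has no number at all in this assay, so its position among the series cannot be placed; only the two limits of its neighbours frame the set, and neither of them is a measured potency.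

The unmeasured compound 4, `O/N=C(/c1nc2ccccc2s1)C1CCCC1`, arises from compound 2 by the change (cyclopentyl in place of 5-methyl-1,2,4-oxadiazol-3-yl on a carbon with a double bond to nitrogen), that is, cyclopentyl in place of 5-methyl-1,2,4-oxadiazol-3-yl on a carbon with a double bond to nitrogen. Going by the values given here, no step between measured compounds exists to calibrate this change, and with compound 2 itself unmeasured no direction can be taken from the data. Given that both measured members reach only a limit in this assay, a step beyond the scatter in either direction is not expected, and compound 4 is most likely to return a limit as well.

Compound 4 is therefore expected to give roughly 100000 nM in this assay, with a range of 30000 nM to 300000 nM.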

Compound 4, half-maximal inhibitory concentration: 83500 nM
Compound 4: the middle estimate sits 1.2-fold (0.08 log units) above what was measured; the measured number falls inside the stated range.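

Working notes on the series: in this assay, compound 4 gives 83500 nM, the only number among the compounds shown, so a cyclopentyl group on a carbon with a double bond to nitrogen leaves the series with one value that can be used as a reference rather than a limit alone. Cyclopentyl in place of methyl at this place gives an at least 1.1-fold lower number from compound 1 to compound 4 (0.07 log units; that floor lies within the scatter), so the one readable step shows no change beyond the scatter, and its true size remains unfixed, with only a floor printed. That floor rests on a limit, and compound 1 holds a limit of the assay, not a number: the limit of > 100000 nM in this assay, at which 1 of the 4 values shown sits.

As far as these compounds go, the exchange of 5-methyl-1,2,4-oxadiazol-3-yl for cyclopentyl, the step from compound 2 to compound 4, cannot be read, so the effect of that aromatic ring against the carbon-only ring remains unknown. Also open, from the compounds shown here alone, is whether an amine, a carboxylic acid or a longer chain on a carbon with a double bond to nitrogen would move the number in this assay beyond the scatter, in either direction, from the value of compound 4.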